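Exchanging the amide substituent: from compound 2 to compound 3

The compounds below may be only part of what the source reports. "The series", "measured", "known", "first", "only" and "open" are said of these compounds alone.

Compound 1 `CCCNC(=O)[C@H](CCC1CCCCC1)NC(=O)c1ccc(CNC(=O)c2cnn(-c3ccccc3)c2N)cc1` in an assay on isolated protein for binding affinity to Discoidin domain-containing receptor 2 (Homo sapiens), read by thermal shift assay, tested at 10 uM (a lower number here means that the compound stabilises the target less, a higher number that the compound stabilises the target more against heat), gives 3.8 degrees C.
Compound 2 `CS(=O)(=O)N1CCC[C@H](NC(=O)[C@H](CCC2CCCCC2)NC(=O)c2ccc(CNC(=O)c3cnn(-c4ccccc4)c3N)cc2)C1` in this assay gives 4.8 degrees C.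

Compound 2 has the higher of the two numbers, but its nearest neighbour, compound 1, sits a step away that is within the scatter: a number 1.0 degrees C higher from compound 1 to compound 2 (within the scatter). Compound 3 `Nc1c(C(=O)NCc2ccc(C(=O)N[C@@H](CCC3CCCCC3)C(=O)NC3CCCN(C4COC4)C3)cc2)cnn1-c1ccccc1` differs from compound 2 by a group of 10 heavy atoms (8 carbon, 1 nitrogen, 1 oxygen; one four-membered non-aromatic ring with 1 hetero atom, one six-membered non-aromatic ring with 1 hetero atom) in place of a group of 10 heavy atoms (6 carbon, 1 nitrogen, 2 oxygen, 1 sulfur; one six-membered non-aromatic ring with 1 hetero atom), on an amide-type nitrogen. Going by the values given here, the one measured step changes the group on this same amide-type nitrogen and stays within the scatter; no measured pair compares the leaving group and the entering group directly. A step of a number 0.30 degrees C lower from compound 2 to compound 3 (within the scatter) is therefore expected, none beyond the scatter. For compound 3 the estimate in this assay is 4.5 degrees C, between 3 degrees C and 6 degrees C.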

Compound 3, shift of the target's melting temperature: 5.8 degrees C
Estimate against measurement, compound 3: 1.3 degrees C below; measured number inside the range.
By their numbers in this assay, from the lowest: compounds 1, 2 and 3 (each within the scatter of the next, the first and the last beyond it).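

Going by these compounds alone, on this amide-type nitrogen, 1-(oxetan-3-yl)piperidin-3-yl is the first group to stand clearly apart from propyl in this assay (a number 2.0 degrees C higher from compound 1 to compound 3 (beyond the scatter)), so a change at this position can move the melting temperature beyond the usual scatter. The two larger groups, however, cannot be told apart (a number 1.0 degrees C higher from compound 2 to compound 3 (within the scatter)). Nothing available explains the result. Going by these compounds, it remains open whether a plain piperidin-3-yl without the oxetane, or a morpholine or a carboxylic acid at this place, would match propyl or the larger groups.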